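The compounds below may be only part of what the source reports. "The series", "measured", "known", "first", "only" and "open" are said of these compounds alone.

In a physicochemical assay for solubility, at pH 7 (on this read-out lower numbers stand for lower solubility and higher numbers for higher solubility), compound 2 `CN1CCC(C(=O)N2Cc3c(NC(=O)c4ccc(F)c(F)c4)n[nH]c3C2(C)C)CC1` gives > 225000 nM, which is a limit of the assay and not a number. Compound 1 `CN1CCC(C(=O)N2Cc3c(NC(=O)c4cccs4)n[nH]c3C2(C)C)CC1`, with thiophen-2-yl on the same carbonyl carbon, gives 155000 nM. For the measured compounds named here, the only measured step bearing on this position is an at least 1.4-fold higher number from compound 1 to compound 2 (0.16 log units; that floor lies within the scatter). As far as these compounds go, its true size remains open, since only a floor is known, and that floor does not exceed the scatter.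

Compound 3 `CN1CCC(C(=O)N2Cc3c(NC(=O)c4ccco4)n[nH]c3C2(C)C)CC1` follows from compound 2 through furan-2-yl in place of 3,4-difluorophenyl on a carbonyl carbon. Going by the values given here, the data hold no measured step to furan-2-yl, so the nearest guide is compound 1 at 155000 nM, the other measured compound without the 3,4-difluorophenyl group. On that basis, no change beyond the scatter is expected in this assay, with any drift more likely toward lower numbers than toward higher ones. The expected change is an at least 1.1-fold lower number from compound 2 to compound 3 (0.07 log units; that floor lies within the scatter). A reading at the limit also remains possible for compound 3. Compound 3 is estimated at 190000 nM, with an expected range of 100000 nM to 300000 nM.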

Compound 3, solubility: > 225000 nM
Compound 3: no number, only a limit; the forecaster's own chance of this, stated with the estimate: 30%; at least 1.1-fold (0.07 log units) between middle value and limit.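

In this assay compound 3 gives > 225000 nM, a limit of the assay and not a number. Furan-2-yl in place of thiophen-2-yl on the carbonyl carbon reads as an at least 1.4-fold higher number from compound 1 to compound 3 (0.16 log units; that floor lies within the scatter), so a second group, a five-membered aromatic ring this time, now stands at the limit alongside 3,4-difluorophenyl, yet this step, like the earlier one, gives only a floor that does not leave the scatter. The step from compound 2 to compound 3 cannot be read, and furan-2-yl and 3,4-difluorophenyl cannot be placed in any order at this position: the limit of > 225000 nM in this assay, at which 2 of the 3 values shown sit.

Open, as far as these compounds go, is whether a group without an aromatic ring on the same carbonyl carbon, such as cyclohexyl or a longer alkyl chain, would give a reading clearly under the limit and so show how far this position can move the read-out. Also open, from the compounds shown here alone, is what an amine or a carboxylic acid carried on the aromatic ring at this position would do in this assay.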